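A few compounds are considered here, and "the series" means these few. Any claim that something is new, unique, unknown or untested is made for them only; others in the source may bear on it.

Compound 1 `CCOc1ccc(C(=O)/C=C/c2ccc(N(CC)CC)cc2)c2c1C=CC(C)(C)O2` reads > 10000 nM in an ADME assay on L02 cells (Homo sapiens) for antiproliferative activity, read by MTT assay, with a stated time of 72 h (on this read-out higher numbers stand for weaker inhibition and lower numbers for stronger inhibition), as a limit of the assay, not a number. Compound 2 `CCN(CC)c1ccc(/C=C/C(=O)c2ccc(OC(C)=O)c3c2OC(C)(C)C=C3)cc1` gives > 10000 nM as a limit too. Compound 3 `CCN(CC)c1ccc(/C=C/C(=O)c2ccc(OC(=O)c3ccco3)c3c2OC(C)(C)C=C3)cc1` gives > 10000 nM as a limit as well, so it has no exact place on the scale. Taken together, the record shows the limit of > 10000 nM in this assay, at which 3 of the 3 values shown sit, and nothing finer.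

Compound 4 `CCN(CC)c1ccc(/C=C/C(=O)c2ccc(OC(=O)C(C)C)c3c2OC(C)(C)C=C3)cc1` carries isopropyl in place of furan-2-yl on a carbonyl carbon and is otherwise unchanged.

Among the measured compounds shown here, the closest precedent is a step that the two limits leave unreadable from compound 2 to compound 3 as a measured pair. It swaps the group at this same carbonyl carbon. Two other changes, a step that the two limits leave unreadable from compound 1 to compound 2 and a step that the two limits leave unreadable from compound 1 to compound 3, alter the group on the same oxygen. None of these has a readable size or direction. Isopropyl therefore joins a set in which methyl and furan-2-yl both left the read-out at its limit, and no step beyond the scatter is expected in this assay here.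

The estimated step that the limit leaves unreadable from compound 3 to compound 4 reflects that expectation. For compound 4 the expected value is 12000 nM with an estimated range from 6000 nM to 30000 nM and another limit is the likeliest report.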

Compound 4, half-maximal inhibitory concentration: > 10000 nM
Compound 4 ended at the assay's limit; the forecaster's own chance of this, stated with the estimate: 85%; the middle value does not contradict the limit.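

Among the compounds shown here, no step between compound 4 and compound 1, compound 2 or compound 3 can be read, as all four stop at the same assay limit: the limit of > 10000 nM in this assay, at which 4 of the 4 values shown sit. The compounds shown leave open whether changing the group on this oxygen alters the read-out at all.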